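The source may hold more compounds than are shown below. What is called first, only, known or untested is meant among the compounds shown, and "the series" means these compounds.

In an assay for binding affinity to leukotriene B4 receptor 1 (Homo sapiens) (a higher number here means a weaker inhibitor, a lower number a stronger inhibitor), compound 2 `Nc1cccc([S+]([O-])Cc2ccc(OCCCCCCCCc3ccc(C(F)(F)F)cc3)c(/C=C/C(=O)O)n2)c1` gives 14 nM. Among the compounds with values here, its only measured neighbour is compound 1 `Nc1cccc([S+]([O-])Cc2ccc(OCCCCCCCCc3ccccc3)c(/C=C/C(=O)O)n2)c1`, which gives 11 nM in this assay, and the step from compound 1 to compound 2 is a 1.3-fold higher number from compound 1 to compound 2 (0.10 log units; within the scatter), so the two stand together. Compound 3 `Nc1cccc([S+]([O-])Cc2ccc(OCCCCCCCCc3ccc(F)cc3)c(/C=C/C(=O)O)n2)c1` differs from compound 2 in one place: fluoro in place of trifluoromethyl on an aromatic carbon. Within the data shown here, the only step that bears on this is the one just named, which stayed within the scatter, so compound 3 is expected to show a 1.2-fold lower number from compound 2 to compound 3 (0.07 log units; within the scatter), no change beyond the scatter. Compound 3 is therefore estimated at 12 nM, with a range from 5 nM to 30 nM.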

Compound 3, inhibition constant: 12 nM
Compound 3: middle estimate and measured number agree at the digits printed; measured number inside the range.
By their numbers in this assay, from the lowest: compounds 1, 3 and 2 (each within the scatter of the next).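

In this assay, fluoro on this aromatic carbon, para to a large group, shows a 1.1-fold higher number from compound 1 to compound 3 (0.04 log units; within the scatter) when it replaces hydrogen and a 1.2-fold lower number from compound 2 to compound 3 (0.07 log units; within the scatter) when it replaces trifluoromethyl. Hydrogen, fluoro and trifluoromethyl therefore cannot be told apart at this position, although the group entering here ranges from a single fluorine to four heavy atoms. Nothing measured explains this lack of separation. Still open, going by these compounds, is whether an amine or a carboxylic acid on this carbon would also stay within the scatter, and whether a shorter or longer chain would change the number.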